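Compound 2 to compound 4: replacing the 2-hydroxyphenyl group

The compounds below may be only part of what the source reports. "The series", "measured", "known", "first", "only" and "open" are said of these compounds alone.

In a functional assay on microsomes for inhibition, with a stated time of 1 h (on this read-out lower numbers stand for stronger inhibition and higher numbers for weaker inhibition), compound 1 `CN(C)c1ccc(-c2nc(NN)n(C)c(=O)c2C#N)cc1` gives 63 ug/mL, compound 2 `CCOC(=O)c1cnn(-c2nc(-c3ccccc3O)c(C#N)c(=O)n2C)c1N` gives 57 ug/mL and compound 3 `Cn1c(NN)nc(-c2cccc(O)c2O)c(C#N)c1=O` gives 31 ug/mL. Compound 2 lies within the usual scatter of both compound 1 and compound 3, so its value sets it apart from neither. Within the data shown here, no two measured compounds differ in one place only, and the series therefore holds no direct measure of what a change at any single position does.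

The next compound is compound 4 `CCOC(=O)c1cnn(-c2nc(-c3ccc(Cl)cc3)c(C#N)c(=O)n2C)c1N`, which differs from compound 2 in one place: 4-chlorophenyl in place of 2-hydroxyphenyl on an aromatic carbon. The exchange puts 4-chlorophenyl in place of 2-hydroxyphenyl on an aromatic carbon, ortho to a cyano group, and the rest of the structure stays the same.

Among the measured compounds shown here, with no measured step to draw on, the best anchor is compound 2 at 57 ug/mL in this assay, the only measured compound that shares everything but this group with compound 4. No clear direction can be expected, and the estimated change, a 1.1-fold lower number from compound 2 to compound 4 (0.06 log units; within the scatter), is expected to stay within the scatter. For compound 4 the expected value is 50 ug/mL, with an estimated range from 20 ug/mL to 120 ug/mL.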

Compound 4, half-maximal inhibitory concentration: 88 ug/mL
Compound 4: the middle estimate sits 1.8-fold (0.25 log units) below what was measured; low and high end bracket the measured number.
By their numbers in this assay, from the lowest: compounds 3, 2, 1 and 4 (each within the scatter of the next, the first and the last beyond it).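

In this assay, among these compounds, the only single-place comparison gives a 1.5-fold higher number from compound 2 to compound 4 (0.19 log units; within the scatter) and so does not resolve 4-chlorophenyl from 2-hydroxyphenyl on this aromatic carbon, ortho to a cyano group. The exchange swaps a hydroxyl-bearing ring, with its hydrogen-bond donor and acceptor, for a chlorine-bearing ring with neither, at an unchanged heavy-atom count, and the read-out still shows no separation between the two groups at this position. No measurement available here accounts for this outcome.

The two groups differ both in the substituent and in where it sits on the phenyl ring, so the effect of each remains unseparated; plain phenyl, 4-hydroxyphenyl or 2-chlorophenyl at this carbon would be needed to tell them apart. Also open, going by these compounds, is whether larger steps appear at this position with a different kind of group, such as an amine or a carboxylic acid on the phenyl ring, and whether the same exchange reads alike when the rest of the molecule differs, as it does in compound 3.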